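This account rests on a few compounds, and the source may have more. Where it says the series, first, only, none or still open, it means among the compounds named here.

Measured so far in an ADME assay on a cell-free system (plasma, Homo sapiens) for metabolic stability; on this read-out lower numbers stand for a shorter-lived compound and higher numbers for a longer-lived compound: compound 1 `O=C(OCc1ccccc1)[C@H]1O[C@@H](Oc2cc3oc(-c4ccc(O)cc4)cc(=O)c3c(O)c2O)[C@H](O)[C@@H](O)[C@@H]1O` gives 1.47 h; compound 2 `CCN(CC)C(=O)COC(=O)[C@H]1O[C@@H](Oc2cc3oc(-c4ccc(O)cc4)cc(=O)c3c(O)c2O)[C@H](O)[C@@H](O)[C@@H]1O` gives 0.167 h; compound 3 `Nc1nc2c(ncn2COCCOC(=O)c2cccc(CN3CCCCC3)c2)c(=O)[nH]1` gives 0.142 h.

Compound 2 stands second highest of these three numbers; compound 3 lies within the scatter of it, while compound 1 sits clearly higher. Compound 4 `CCOC(=O)[C@H]1O[C@@H](Oc2cc3oc(-c4ccc(O)cc4)cc(=O)c3c(O)c2O)[C@H](O)[C@@H](O)[C@@H]1O` differs from compound 2 only by methyl in place of diethylcarbamoyl on a saturated chain carbon bound to an oxygen next to a carbonyl group. Among the measured compounds shown here, the one measured step that touches this position, an 8.8-fold lower number from compound 1 to compound 2 (0.94 log units; beyond the scatter), shows that the group on this carbon can shift the half-life beyond the scatter. For the measured compounds named here, no measured step tells how a methyl group behaves there, so the direction stays uncertain; a move back toward compound 1 is plausible but not assured. Compound 4 is expected at 0.7 h, ranging from 0.25 h to 2 h, which means an estimated 4.2-fold higher number from compound 2 to compound 4 (0.62 log units; beyond the scatter).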

Compound 4, half-life: 4.55 h
For compound 4 the middle estimate is 6.5-fold (0.81 log units) below the measured one; the whole stated range lies below it.
By their numbers in this assay, from the lowest: compounds 3 and 2 (each within the scatter of the next); then compound 1; then compound 4.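

Methyl in place of diethylcarbamoyl on this carbon gives a 27-fold higher number from compound 2 to compound 4 (1.44 log units; beyond the scatter) in this assay, the largest step seen at this position, and it runs opposite to the drop seen with diethylcarbamoyl. Methyl in place of phenyl gives a 3.1-fold higher number from compound 1 to compound 4 (0.49 log units; beyond the scatter) as well, so phenyl is not the top of the range here: the half-life rises from diethylcarbamoyl to phenyl to methyl. From the compounds shown here alone, whether a longer chain or an amine on this carbon would keep the half-life near that of compound 4 stays open. No measured evidence here accounts for the size of these steps.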